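Shortening the Ether Chain on a Chromanone Core

A few compounds are considered here, and "the series" means these few. Any claim that something is new, unique, unknown or untested is made for them only; others in the source may bear on it.

Measured compounds:
compound 1 `C=CCOc1ccccc1C1CC(=O)c2ccccc2O1`, in a functional assay on RAW264.7 cells (Mus musculus) for inhibition, read by immunoassay, with a stated time of 12 h, tested at 30 uM (on this read-out higher numbers stand for more inhibition at the one concentration tested (going by the name of the read-out) and lower numbers for less inhibition), compound 1 gives 49.3%
compound 2 `CCCCOc1ccccc1C1CC(=O)c2ccccc2O1`, in this assay compound 2 gives 19.3%

Compound 2 stands lowest of the two numbers; its nearest neighbour is compound 1, higher by a number 30 percentage points lower from compound 1 to compound 2 (beyond the scatter). Compound 3 `COc1ccccc1C1CC(=O)c2ccccc2O1` differs from compound 2 by hydrogen in place of propyl on a saturated chain carbon bound to an oxygen on an aromatic ring. Within the data shown here, only the step from compound 1 to compound 2 bears on this change, and it was modest: a number 30 percentage points lower from compound 1 to compound 2 (beyond the scatter). That step concerns a different replacement at the same place, so it gives weak guidance. A step of a number 10.7 percentage points higher from compound 2 to compound 3 (beyond the scatter) is expected in this assay, upward but uncertain. Compound 3 is estimated at 30%, within 10% to 55%.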

Compound 3, a percentage reported as inhibition, at one concentration (the size of the read-out at that concentration, not a potency): 37.3%
For compound 3 the middle estimate is 7.3 percentage points below the measured one, within the range that was stated.
By their numbers in this assay, from the lowest: compound 2; then compound 3; then compound 1.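

Shortening the butoxy group to methoxy gives (a number 18 percentage points higher from compound 2 to compound 3 (beyond the scatter)), so at this place a chain loss can raise the number, which the earlier pair could not show. Hydrogen in place of vinyl gives (a number 12 percentage points lower from compound 1 to compound 3 (beyond the scatter)), so compound 1 goes against any rule that the shorter chain reads higher. Nothing shown explains these differences.

The compounds shown leave open how a chain longer than butyl, or an amine or a carboxylic acid at the end of the chain, would read at this place.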